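Lengthening the Linker Chain in a Sigma-1 Series

The compounds below may be only part of what the source reports. "The series", "measured", "known", "first", "only" and "open" are said of these compounds alone.

In an assay on cell membranes for displacement of a labelled ligand from Sigma non-opioid intracellular receptor 1 (Rattus norvegicus) (a lower number here means a stronger inhibitor, a higher number a weaker inhibitor), compound 1 `CCC(=O)c1ccc2c(c1)sc(=O)n2CCCCN1CCCCCC1` gives 10.3 nM. Compound 2 `CCC(=O)c1ccc2c(c1)sc(=O)n2CCCCCN1CCCCCC1` differs from it by (azepan-1-yl)methyl in place of azepan-1-yl on a saturated chain carbon, four bonds along the chain from an aromatic nitrogen, and in this assay compound 2 gives 12.2 nM, so a 1.2-fold higher number from compound 1 to compound 2 (0.07 log units; within the scatter). Compound 3 `CCCc1ccc2c(c1)sc(=O)n2CCCCCN1CCCCCC1` gives 4.6 nM in this assay, and a 2.7-fold lower number from compound 2 to compound 3 (0.42 log units; beyond the scatter). The difference between the cores of compound 1 and compound 3 is not broken down here. Compound 4 `CCCc1ccc2c(c1)sc(=O)n2CCCCCCN1CCCCCC1` has not yet been measured; it differs from compound 3 by (azepan-1-yl)methyl in place of azepan-1-yl on a saturated chain carbon, five bonds along the chain from an aromatic nitrogen. This is the same kind of change as that between compound 1 and compound 2, though there the place was four bonds along the chain from an aromatic nitrogen and here it is five bonds along the chain. Because that earlier step was a 1.2-fold higher number from compound 1 to compound 2 (0.07 log units; within the scatter), the expected step here is a 1.2-fold higher number from compound 3 to compound 4 (0.08 log units; within the scatter). Compound 4 is therefore estimated at 5.5 nM, with a likely range from 2.5 nM to 12 nM.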

Compound 4, inhibition constant: 6.3 nM
Compound 4: middle estimate off by 1.1-fold (0.06 log units), on the low side; low and high end bracket the measured number.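

With (azepan-1-yl)methyl in place of azepan-1-yl, this assay gives a 1.4-fold higher number from compound 3 to compound 4 (0.14 log units; within the scatter). Set beside the earlier case, the two steps agree: the same change on two cores in this assay, a 1.2-fold higher number (0.07 log units; within the scatter) from compound 1 to compound 2 and a 1.4-fold higher number (0.14 log units; within the scatter) from compound 3 to compound 4, 1.2-fold (0.06 log units) apart, within the scatter of two such steps. This change therefore carries from one core to the other here, leaving the number essentially unchanged each time, but two small steps on two cores do not show that it would behave the same way on any other core or at any other chain length.

The compounds shown leave open whether a still longer chain would keep the number in this range. They also leave open what a shorter chain, or a piperidine in place of the azepan-1-yl group, would do.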